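Piperazine series: thiophene analogue of the diaryl-methyl group

This account rests on a few compounds, and the source may have more. Where it says the series, first, only, none or still open, it means among the compounds named here.

Measured compounds in a functional assay on cells (Rhabdomyosarcoma cell, Homo sapiens) for cytotoxicity; a higher number here means a weaker inhibitor, a lower number a stronger inhibitor:
- compound 1 `Cc1ccccc1C(c1ccccc1)N1CCN(c2ncnc3c2cnn3-c2ccccc2)CC1` gives > 25000 nM, a limit of the assay.
- compound 2 `c1ccc(C(c2ccccn2)N2CCN(c3ncnc4c3cnn4-c3ccccc3)CC2)cc1` gives > 25000 nM, also a limit of the assay.

Compound 1 stands only at a limit in this assay, not at a number. Going by the values given here, the one step with measured ends, a step that the two limits leave unreadable from compound 1 to compound 2, cannot be sized, since both ends are limits. The whole evidence on the series is the limit of > 25000 nM in this assay, at which 2 of the 2 values shown sit.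

Compound 3 `Cc1ccsc1C(c1ccccc1)N1CCN(c2ncnc3c2cnn3-c2ccccc2)CC1` is not yet measured. It differs from compound 1 thus: 3-methylthiophen-2-yl in place of 2-methylphenyl on a saturated chain carbon bound to an amine nitrogen in a ring and an aromatic carbon. Among the compounds with values here, no measured step touches a thiophene at this position, and the only step measured at all, from a 2-methylphenyl to a pyridin-2-yl group on the same carbon, yields no readable size. The expectation for compound 3 therefore rests on compound 1 alone, which sits at the limit, and on (the limit of > 25000 nM in this assay, at which 2 of the 2 values shown sit).

For compound 3 the estimated value in this assay is 30000 nM, with a range of 8000 nM to 120000 nM, most likely again reported as a limit. The step that this estimate means, a step that the limit leaves unreadable from compound 1 to compound 3, is expected to stay unreadable.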

Compound 3, half-maximal inhibitory concentration: > 25000 nM
Compound 3 gave a limit, no number; the forecaster's own chance of this, stated with the estimate: 75%; the middle value does not contradict the limit.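

No step among compound 1, compound 2 and compound 3 can be read in this assay, as all three stand only at a limit of the assay: the limit of > 25000 nM in this assay, at which 3 of the 3 values shown sit.

The compounds shown leave open whether any group on the saturated chain carbon gives a measurable number in this assay.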